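The compounds below may be only part of what the source reports. "The series", "measured", "known", "first", "only" and "open" are said of these compounds alone.

Working notes on the series, with every value read in a functional assay on ECa-109 cells (Homo sapiens) for cytotoxicity, read by MTT assay, with a stated time of 72 h; on this read-out higher numbers stand for weaker inhibition and lower numbers for stronger inhibition. Compound 1 (`COc1cccc(C=C2C(=O)N(c3ccc(Cl)cc3)N(c3ccc(Cl)cc3)C2=O)c1O`) gives 39000 nM. Compound 2 (`COc1ccc(C=C2C(=O)N(c3ccc(Cl)cc3)N(c3ccc(Cl)cc3)C2=O)cc1`) gives > 128000 nM, which is a limit and not a number. Compound 3 (`COc1ccc(C=C2C(=O)N(c3ccc(Cl)cc3)N(c3ccc(Cl)cc3)C2=O)cc1OC`) gives > 128000 nM, which is likewise a limit, so the starting point for this step is not a number.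

The change leading to compound 4 (`O=C1C(=Cc2c[nH]c3ccccc23)C(=O)N(c2ccc(Cl)cc2)N1c1ccc(Cl)cc1`) is 1H-indol-3-yl in place of 3,4-dimethoxyphenyl on a double-bonded chain carbon bound to a double-bonded ring carbon. In words, 1H-indol-3-yl stands in place of 3,4-dimethoxyphenyl on a double-bonded chain carbon bound to a double-bonded ring carbon.

All measured steps concern the group at this same place. The first two are an at least 3.2-fold higher number from compound 1 to compound 2 (0.51 log units; beyond the scatter) and an at least 3.2-fold higher number from compound 1 to compound 3 (0.51 log units; beyond the scatter). The third is a step that the two limits leave unreadable from compound 2 to compound 3, and it adds nothing on size. These steps show that the group at this place can shift the read-out, but none of them involves 1H-indol-3-yl, so they transfer only loosely. Among the measured compounds shown here, the one measured number, compound 1 at 39000 nM, sets the likely level if the new group gives a measurable number.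

A modest move to a lower number is expected, with the estimated step being an at least 2.1-fold lower number from compound 3 to compound 4 (0.32 log units; beyond the scatter). For compound 4 the estimated value is 60000 nM, with an expected range of 18000 nM to 170000 nM.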

Compound 4, half-maximal inhibitory concentration: 23400 nM
Compound 4: the middle estimate sits 2.6-fold (0.41 log units) above what was measured; the measured number falls inside the stated range.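

In this assay, 1H-indol-3-yl at this place, on a double-bonded chain carbon bound to a double-bonded ring carbon, gives a measured number where the methoxy-only phenyl groups give none: an at least 5.4-fold lower number from compound 3 to compound 4 (0.73 log units; beyond the scatter) and an at least 5.4-fold lower number from compound 2 to compound 4 (0.73 log units; beyond the scatter). The earlier compounds shown here showed a readable number only with 2-hydroxy-3-methoxyphenyl, and this result shows that a readable number does not depend on that group, since the comparison yields a 1.7-fold lower number from compound 1 to compound 4 (0.22 log units; within the scatter), so the two groups cannot be told apart here. Both steps out of the methoxy-only compounds are bounds and not sizes, with compound 2 and compound 3 each standing at a limit of the assay: the limit of > 128000 nM in this assay, at which 2 of the 4 values shown sit.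

The compounds shown leave open whether the hydrogen-bond donor counted on 1H-indol-3-yl matters, which a 1-methylindol-3-yl group, with a methyl on the ring nitrogen, would test directly. They also leave open how an amine or a carboxylic acid on the aromatic ring at this place would read, and whether anything in the shared core would shift the number further.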